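Extending an Acetyl to an Aryl Ketone

The source may report more compounds than this note shows. Statements on the series, on what has been measured and on what is new or still open speak of the compounds shown alone.

Measured so far:
compound 1, `COc1ccc(C(=O)/C=C/c2ccc(OCCNc3ccnc4cc(Cl)ccc34)c(OC)c2)c(OC)c1`, 4.2
compound 2, `COc1cc(/C=C/C(C)=O)ccc1OCc1cn(-c2ccnc3cc(Cl)ccc23)nn1`, 3.6

In a physicochemical assay for lipophilicity, read by HPLC, at pH 7.4 (a higher number here means a more lipophilic compound, a lower number a more polar compound), compound 1 gives 4.2, while compound 2 gives 3.6. Of the two measured compounds, compound 2 stands at the lower number, and its distance from compound 1 lies beyond the usual scatter of such measurements. For the measured compounds named here, no pair of measured compounds differs in only one place, so no single step can be read directly from them.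

Compound 3, `COc1ccc(C(=O)/C=C/c2ccc(OCc3cn(-c4ccnc5cc(Cl)ccc45)nn3)c(OC)c2)c(OC)c1`, has not yet been measured in this assay. It differs from compound 2 in one place: 2,4-dimethoxyphenyl in place of methyl on a carbonyl carbon. Cut one bond further out, the change reads acetyl to (2,4-dimethoxyphenyl)carbonyl.

The change replaces a methyl with the much larger 2,4-dimethoxyphenyl group, which brings in an aromatic ring. A rise in the distribution coefficient beyond the scatter is expected, and the step from compound 2 to compound 3 is estimated at a number 1.30 log units higher from compound 2 to compound 3 (beyond the scatter). Compound 3 is accordingly expected to give about 4.9, with a likely range from 4.3 to 5.5.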

Compound 3, distribution coefficient: 4.3
For compound 3 the middle estimate is 0.60 log units above the measured one, and the stated range covers the measured number.
By their numbers in this assay, from the lowest: compound 2; then compounds 1 and 3 (each within the scatter of the next).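

In this assay the series now has its first step at a single place: 2,4-dimethoxyphenyl in place of methyl on a carbonyl carbon gives a number 0.70 log units higher from compound 2 to compound 3 (beyond the scatter) in the distribution coefficient. This shows that the read-out responds to a change at this carbonyl carbon, whose other neighbour is a double-bonded chain carbon, and that exchanging the single methyl for the substituted aromatic ring moves the number by more than the scatter. For the compounds shown here, no supporting measurement accounts for the size of this step, so the single pair gives its size and direction and nothing more.

With only this one exchange at the position, the compounds shown leave open how much of the step belongs to the aromatic ring itself and how much to its two methoxy groups, a question that an unsubstituted phenyl or a simple ethyl on the same carbonyl carbon would address. They also leave open whether a group of a different kind there, such as a morpholine-bearing chain or a carboxylic acid, would move the number in the same direction or the opposite one.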